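Aryl variation at the pyridine position in a TRPV1 series

The source may hold more compounds than are shown below. What is called first, only, known or untested is meant among the compounds shown, and "the series" means these compounds.

Measured so far:
- compound 1, `CC(C(=O)NCc1ccc(C(F)(F)F)nc1-c1cccc(Cl)c1)c1ccc(NS(C)(=O)=O)c(F)c1`: in an assay on CHO cells for antagonist activity at transient receptor potential cation channel subfamily V member 1 (Homo sapiens), read by FLIPR (on this read-out lower numbers stand for stronger inhibition and higher numbers for weaker inhibition), compound 1 gives 0.5 nM
- compound 2, `CC(C(=O)NCc1ccc(C(F)(F)F)nc1-c1ccc(N(C)C)cc1)c1ccc(NS(C)(=O)=O)c(F)c1`: compound 2 gives 3.2 nM
- compound 3, `CC(C(=O)NCc1ccc(C(F)(F)F)nc1-c1ccc(C(C)(C)C)cc1)c1ccc(NS(C)(=O)=O)c(F)c1`: compound 3 gives 0.5 nM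

Compound 1 stands level with compound 3 at the digits shown, and the two together hold the lowest numbers of the three; compound 2 sits furthest away, a 6.4-fold higher number from compound 1 to compound 2 (0.81 log units; beyond the scatter).

The next compound, compound 4, `CC(C(=O)NCc1ccc(C(F)(F)F)nc1-c1ccc2cc[nH]c2c1)c1ccc(NS(C)(=O)=O)c(F)c1`, changes the same aromatic carbon of the shared core as the two measured steps do: 1H-indol-6-yl in place of 3-chlorophenyl on an aromatic carbon.

Among the compounds with values here, two steps bear on this position. Within the data shown here, the first, a 6.4-fold higher number from compound 1 to compound 2 (0.81 log units; beyond the scatter), is the only step beyond the scatter in the set. The second, no change at the digits printed from compound 1 to compound 3 (within the scatter), shows a group of comparable bulk being taken without a visible shift. The swap from compound 2 to compound 3, a 6.4-fold lower number from compound 2 to compound 3 (0.81 log units; beyond the scatter), mirrors the first. Nothing measured carries a hydrogen-bond donor at this position, so the new group is outside the range covered. Among the measured compounds shown here, a small loss in this assay, smaller than the one seen for compound 2, is expected rather than a gain.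

For compound 4 the expected value in this assay is 1.3 nM, with a range from 0.4 nM to 5 nM, which means an expected step of a 2.6-fold higher number from compound 1 to compound 4 (0.41 log units; beyond the scatter).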

Compound 4, inhibition constant: 20.3 nM
Beside the measured number, compound 4's estimate is 16-fold (1.19 log units) below it; measured number above the stated range.
By their numbers in this assay, from the lowest: compounds 1 and 3 (each within the scatter of the next); then compound 2; then compound 4.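

In this assay, the 1H-indol-6-yl group produces the largest steps seen at this position, both from 3-chlorophenyl (a 41-fold higher number from compound 1 to compound 4 (1.61 log units; beyond the scatter)) and from 4-(tert-butyl)phenyl (a 41-fold higher number from compound 3 to compound 4 (1.61 log units; beyond the scatter)), so the position does not accept every aryl group equally. Within the data shown here, the step from the 4-(dimethylamino)phenyl compound (a 6.3-fold higher number from compound 2 to compound 4 (0.80 log units; beyond the scatter)) shows that compound 4 also lies beyond the scatter from the highest earlier number, and it is the only compound of the four with a hydrogen-bond donor or a five-membered aromatic ring in this group. No supporting data bear on what lies behind this loss.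

The compounds shown leave open whether the loss follows the indole nitrogen hydrogen, the fused ring pair or the point of attachment, since all three change together in this single group. A 1-methyl-1H-indol-6-yl group, a 2-naphthyl group and a 1H-indol-5-yl group at the same aromatic carbon would each separate one of these features from the others.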